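The source may report more compounds than this note shows. Statements on the series, on what has been measured and on what is new or still open speak of the compounds shown alone.

Measured so far in a functional assay on HT-29 cells (Homo sapiens) for antiproliferative activity, read by sulforhodamine B assay, with a stated time of 48 h; on this read-out lower numbers stand for stronger inhibition and higher numbers for weaker inhibition:
compound 1 `CCCCc1ccc(NS(=O)(=O)c2ccc(N3CCNC3=O)cc2)cc1` gives 610 nM
compound 2 `Cc1ccc(NS(=O)(=O)c2ccc(N3CCNC3=O)cc2)cc1C` gives 230 nM

Of these two, compound 1 has the higher number, and its gap to compound 2 lies beyond the usual scatter, so compound 2 holds the cell growth back more strongly. Compound 3 `CCCCCCOc1ccc(NS(=O)(=O)c2ccc(N3CCNC3=O)cc2)cc1` is not yet measured. It differs from compound 1 by hexyloxy in place of butyl on an aromatic carbon. For the measured compounds named here, no measured pair shows what such a change does here, so in this assay the step is expected to be small, in no firm direction. Compound 3 is therefore estimated at 500 nM, within 150 nM to 2000 nM. That estimate means an expected step of a 1.2-fold lower number from compound 1 to compound 3 (0.09 log units; within the scatter).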

Compound 3, half-maximal inhibitory concentration: > 1000 nM
Compound 3 gave a limit, no number; the forecaster's own chance of this, stated with the estimate: 5%; middle value at least 2.0-fold (0.30 log units) away from the limit.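

In this assay compound 3 gives > 1000 nM, which is a limit of the assay and not a number. Hexyloxy in place of butyl at this position gives an at least 1.6-fold higher number from compound 1 to compound 3 (0.21 log units; that floor lies within the scatter), so the longer group brings no gain in holding back cell growth, though this floor alone does not establish a loss.

Hexyloxy differs from butyl in both chain length and its oxygen, and this single step cannot separate the two. On these data alone, a butoxy or hexyl chain on the same carbon would tell them apart, and the effect of an amine there remains open.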